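A few compounds are considered here, and "the series" means these few. Any claim that something is new, unique, unknown or untested is made for them only; others in the source may bear on it.

Working notes on the cytotoxicity series.

Three members of the series have been run in an ADME assay on Vero cells (Chlorocebus sabaeus) for cytotoxicity, read by MTT assay, with a stated time of 72 h (a higher number here means a weaker inhibitor, a lower number a stronger inhibitor), and none returned a number. Compound 1 `CCn1cc(C(=O)N2N=C(c3cc4ccccc4o3)CC2c2ccccc2O)c(=O)c2ccc(C)nc21` reached only the limit of > 157000 nM in this assay. Compound 2 `CCn1cc(C(=O)N2N=C(c3cc4ccccc4o3)CC2c2ccc(O)cc2)c(=O)c2ccc(C)nc21` likewise stopped at the limit of > 148000 nM. Compound 3 `CCn1cc(C(=O)N2N=C(c3cc4ccccc4o3)CC2c2ccccc2)c(=O)c2ccc(C)nc21` also gave only a limit, > 210000 nM, and so stands among three values of which every one is a limit, as the limit of > 148000 nM in this assay, at which 1 of the 3 values shown sits, the limit of > 157000 nM in this assay, at which 1 of the 3 values shown sits, and the limit of > 210000 nM in this assay, at which 1 of the 3 values shown sits, record. The steps between these compounds are therefore blank: a step that the two limits leave unreadable from compound 1 to compound 2, a step that the two limits leave unreadable from compound 1 to compound 3 and a step that the two limits leave unreadable from compound 2 to compound 3 all remain unreadable.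

Compound 4 `CCn1cc(C(=O)N2N=C(c3cc4ccccc4o3)CC2/C=C/c2ccccc2)c(=O)c2ccc(C)nc21` is the next member. It differs from compound 3 by 2-phenylethenyl in place of phenyl on a saturated ring carbon. Among the measured compounds shown here, no measured step in this assay can be read, so nothing points toward a shift in either direction; the working expectation is that compound 4 will again sit at or near the limit, giving 200000 nM with a range of 60000 nM to 300000 nM, which as a step means an at least 1.0-fold lower number from compound 3 to compound 4 (0.02 log units; that floor lies within the scatter) expected, essentially no change beyond the scatter.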

Compound 4, half-maximal inhibitory concentration: > 168000 nM
Compound 4 was reported as a limit; the forecaster's own chance of this, stated with the estimate: 80%; the middle value does not contradict the limit.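

Compound 4 gave only a limit, as did compound 1, compound 2 and compound 3, so its steps from those three compounds cannot be read. The compounds shown leave open whether any group on the saturated ring carbon changes the result in this assay.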